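The source may hold more compounds than are shown below. What is called first, only, known or untested is meant among the compounds shown, and "the series" means these compounds.

In a functional assay on SR cells (Homo sapiens) for inhibition, read by sulforhodamine B assay, with a stated time of 48 h (a lower number here means a stronger inhibitor of growth, a higher number a weaker inhibitor of growth), compound 1 `COc1cc(-c2cc(/C=C/C(=O)c3ccc(N)cc3)[nH]n2)cc(OC)c1OC` gives 2750 nM. Compound 2 `COc1ccc(-c2cc(/C=C/C(=O)c3cc(OC)c(OC)c(OC)c3)[nH]n2)cc1OC` gives 2260 nM in this assay, and the two numbers lie within the usual scatter of each other, so neither compound can be placed ahead of the other. Compound 3 `COc1ccc(C(=O)/C=C/c2cc(-c3cc(OC)c(OC)c(OC)c3)n[nH]2)cc1` has not yet been measured in this assay. It differs from compound 1 in one place: methoxy in place of amino on an aromatic carbon. Among the compounds with values here, the two measured compounds do not include any pair that differs at only one position, so there is no measured step from which to judge how this particular change plays out. On that basis the writer expects a step from compound 1 to compound 3 in this assay of a 1.1-fold lower number from compound 1 to compound 3 (0.02 log units; within the scatter), one that does not go beyond the scatter in either direction. Compound 3 is therefore estimated to give 2600 nM in this assay, within a range from 1000 nM to 6500 nM.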

Compound 3, concentration for total growth inhibition: 23900 nM
For compound 3 the middle estimate is 9.2-fold (0.96 log units) below the measured one, outside the stated range (above it).
By their numbers in this assay, from the lowest: compounds 2 and 1 (each within the scatter of the next); then compound 3.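

In this assay, putting methoxy in place of amino on the aromatic carbon para to a large group gives an 8.7-fold higher number from compound 1 to compound 3 (0.94 log units; beyond the scatter). Within the data shown here, this is the first single-place step, and it shows that growth inhibition in these cells is sensitive to the group at this position: 4-aminophenyl and 4-methoxyphenyl are not interchangeable on this core. No measurement shown here explains the size or direction of this step.

The compounds shown leave open whether the amino group is specifically required, since a hydroxyl, a methylamino or a dimethylamino group, or plain hydrogen, at this carbon would each separate the effect of losing amino from that of adding methoxy. They also leave open whether the same exchange would give a comparable step at another position on the ring.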